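The source may hold more compounds than are shown below. What is called first, only, known or untested is meant among the compounds shown, and "the series" means these compounds.

Compound 1 `O=C1Nc2ccc(F)cc2/C1=C\C(=O)c1ccc(O)cc1F`: 6120 nM
Compound 2 `O=C1Nc2ccc(F)cc2/C1=C\C(=O)c1ccc(C2CCCCC2)cc1`: 4450 nM

In a functional assay on BGC-823 cells (Homo sapiens) for inhibition, read by sulforhodamine B assay, with a stated time of 3 days (on this read-out lower numbers stand for stronger inhibition and higher numbers for weaker inhibition), compound 2 gives 4450 nM and compound 1 gives 6120 nM, so the two stand within the usual scatter of each other. Compound 3 `O=C1Nc2ccc([N+](=O)[O-])cc2/C1=C\C(=O)c1ccc(C2CCCCC2)cc1` keeps everything in compound 2 except one group, with nitro in place of fluoro on an aromatic carbon. Among the compounds with values here, no measured pair shows what this swap does in this assay, so no step beyond the scatter is expected, and neither direction is favoured. The estimated change is a 1.1-fold lower number from compound 2 to compound 3 (0.05 log units; within the scatter). Compound 3 is expected at about 4000 nM, with an estimated range from 1300 nM to 12000 nM.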

Compound 3, half-maximal inhibitory concentration: 5900 nM
For compound 3 the middle estimate is 1.5-fold (0.17 log units) below the measured one; low and high end bracket the measured number.
By their numbers in this assay, from the lowest: compounds 2, 3 and 1 (each within the scatter of the next).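

In this assay, replacing fluoro with nitro gives a 1.3-fold higher number from compound 2 to compound 3 (0.12 log units; within the scatter), a step within the scatter. This aromatic carbon therefore takes nitro, with its three heavy atoms and two hydrogen-bond acceptors, in place of a single fluorine without a readable shift in the number. No measurement shown here offers an explanation for this result. Still open, as far as these compounds go, is whether an amine or a carboxylic acid on this same carbon would move the number beyond the scatter.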